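The source may hold more compounds than are shown below. What is called first, only, known or untested is meant among the compounds shown, and "the series" means these compounds.

Compound 1 `O=C(CCCCCCc1ccccc1)c1nnc(-c2ccccc2)[nH]1`: > 10000 nM in an assay on HEK-293T cells for inhibition of diacylglycerol lipase-alpha (Homo sapiens), read by colorimetric assay; a higher number here means a weaker inhibitor, a lower number a stronger inhibitor. Compound 2 `CN(C)C(=O)c1coc(C(=O)CCCCCCc2ccccc2)n1`: 3390 nM in this assay.

Among the measured compounds shown here, compound 2 gives the only number in this assay; the other result is a limit. For compound 1 the result > 10000 nM is a limit of this assay, (the limit of > 10000 nM in this assay, at which 1 of the 2 values shown sits). Compound 3 `O=C(CCCCCCc1ccccc1)c1nc(-c2ccccn2)co1` differs from compound 2 by pyridin-2-yl in place of dimethylcarbamoyl on an aromatic carbon. No step between measured compounds is shown, so the step of a 1.7-fold lower number from compound 2 to compound 3 (0.23 log units; within the scatter) is only an expectation: a gain in this assay of about the usual scatter. Compound 3 is estimated at 2000 nM, between 500 nM and 8000 nM.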

Compound 3, half-maximal inhibitory concentration: > 10000 nM
Compound 3: a limit, no number; the forecaster's own chance of this, stated with the estimate: 20%; middle value at least 5.0-fold (0.69 log units) from the limit.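

On the aromatic carbon next to the ring nitrogen, pyridin-2-yl in place of dimethylcarbamoyl gives an at least 2.9-fold higher number from compound 2 to compound 3 (0.46 log units; beyond the scatter), so this position does not tolerate every group it is given. From the compounds shown here alone, the result for compound 3 is a limit of this assay, so the true size of this loss stays open on the upper side: the limit of > 10000 nM in this assay, at which 2 of the 3 values shown sit.

The compounds shown leave open whether the amide carbonyl or the two methyl groups of dimethylcarbamoyl carry the activity of compound 2. A primary carboxamide, a methyl ester or a carboxylic acid at this position would address that, and phenyl would test the pyridine nitrogen.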